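This account rests on a few compounds, and the source may have more. Where it says the series, first, only, none or still open, it means among the compounds named here.

In a toxicity assay on THP-1 cells (Homo sapiens) for inhibition (a higher number here means that more compound is tolerated, a lower number that less compound is tolerated), compound 1 `Cn1c(-c2ccccc2F)cnc1NC(=O)c1ccc(F)cc1` gives > 100000 nM, and this value is a limit of the assay, not a number.

Compound 2 `CCn1c(-c2ccc(OC)cc2)cnc1NC(=O)c1ccc(F)cc1` gives > 100000 nM, which is likewise a limit. Compound 2 therefore has no exact value, and it stands with compound 1 at the only level seen so far, (the limit of > 100000 nM in this assay, at which 2 of the 2 values shown sit).

Compound 3 `COc1ccc(-c2cnc(NC(=O)c3ccc(F)cc3)n2C(C)C)cc1` has not yet been measured. It differs from compound 2 in one place, where ethyl becomes isopropyl: methyl in place of hydrogen on a saturated chain carbon bound to an aromatic nitrogen and a saturated chain carbon. Put another way, a methyl replaces a hydrogen on a saturated chain carbon bound to an aromatic nitrogen and a saturated chain carbon.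

For the measured compounds named here, no two measured compounds differ in just one place, so the data give no direct measure of what a single change does in this assay. With compound 2 at > 100000 nM, the expectation is no step beyond the usual scatter, and another reading at the limit is the likeliest result. The estimated step of a number no higher from compound 2 to compound 3 (the limit leaves the size open) is expected to be small. Compound 3 is expected to give about 100000 nM, with an estimated range from 50000 nM to 200000 nM.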

Compound 3, half-maximal cytotoxic concentration: > 50000 nM
Compound 3: no number, only a limit; the forecaster's own chance of this, stated with the estimate: 85%; the middle value lies beyond the limit too.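

Compound 2 and compound 3 both give limits of the assay rather than numbers, and the step between them cannot be read in this assay. The compounds shown leave open the concentration at which any of them would reach half-maximal cytotoxicity, and whether the change from ethyl to isopropyl alters how much compound is tolerated.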